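Biphenyl sulfonamide expected near the tert-butyl analogue

The compounds below may be only part of what the source reports. "The series", "measured", "known", "first", "only" and "open" are said of these compounds alone.

Compound 1 `COc1cc2nc(N3CCN(S(=O)(=O)c4cccc([N+](=O)[O-])c4)CC3)nc(N)c2cc1OC`: 32000 nM
Compound 2 `COc1cc2nc(N3CCN(S(=O)(=O)c4ccc(C(F)(F)F)cc4)CC3)nc(N)c2cc1OC`: 27000 nM
Compound 3 `COc1cc2nc(N3CCN(S(=O)(=O)c4ccc(C(C)(C)C)cc4)CC3)nc(N)c2cc1OC`: 4100 nM

In a functional assay on PC-3 cells (Homo sapiens) for inhibition (a higher number here means a weaker inhibitor, a lower number a stronger inhibitor), compound 3 holds the lowest number of the three, its nearest neighbour being compound 2 (a 6.6-fold lower number from compound 2 to compound 3 (0.82 log units; beyond the scatter)), the furthest compound 1 (a 7.8-fold lower number from compound 1 to compound 3 (0.89 log units; beyond the scatter)). Compound 4 `COc1cc2nc(N3CCN(S(=O)(=O)c4ccc(-c5ccccc5)cc4)CC3)nc(N)c2cc1OC` differs from compound 3 in one place: phenyl in place of tert-butyl on an aromatic carbon. Going by the values given here, the steps that bear on this are the two that reach compound 3, since each replaces a smaller group on the same ring with tert-butyl, and both were modest. Among the compounds with values here, no step between two groups of comparable count exists. Compound 4 is therefore expected to land close to compound 3, with a 1.4-fold lower number from compound 3 to compound 4 (0.14 log units; within the scatter). The estimate for compound 4 is 3000 nM, within 800 nM to 12000 nM.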

Compound 4, half-maximal inhibitory concentration: 4200 nM
Compound 4: the middle estimate sits 1.4-fold (0.15 log units) below what was measured, and the stated range covers the measured number.
By their numbers in this assay, from the lowest: compounds 3 and 4 (each within the scatter of the next); then compounds 2 and 1 (each within the scatter of the next).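

In this assay, phenyl and tert-butyl cannot be told apart on this aromatic carbon (a 1.0-fold higher number from compound 3 to compound 4 (0.01 log units; within the scatter)), so a ring of six carbons serves here as well as the branched group. Compound 4 also keeps the modest separation seen for compound 3 from the other two compounds (a 6.4-fold lower number from compound 2 to compound 4 (0.81 log units; beyond the scatter); a 7.6-fold lower number from compound 1 to compound 4 (0.88 log units; beyond the scatter)). No measurement at hand explains this equivalence. On these data alone, whether an amine, a carboxylic acid or a longer alkyl chain at this carbon would give a similar number remains open.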